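This account rests on a few compounds, and the source may have more. Where it says the series, first, only, none or still open, it means among the compounds named here.

Measured so far in an assay on HEK293 cells for inhibition of kynurenine 3-monooxygenase (Homo sapiens), read by LC-MS, with a stated time of 20 h; on this read-out higher numbers stand for weaker inhibition and lower numbers for stronger inhibition:
compound 1 `Cc1ccc([C@@H](C)Oc2cc3oc(=O)n(CCC(=O)O)c3cc2Cl)nc1` gives 6.31 nM
compound 2 `CCOc1cc2oc(=O)n(CCC(=O)O)c2cc1Cl` gives 398 nM

For the measured compounds named here, compound 2 stands highest of the two numbers in this assay; the only step within the data is a 63-fold higher number from compound 1 to compound 2 (1.80 log units; beyond the scatter), a large one. Compound 3 `Cc1ccnc([C@@H](C)Oc2cc3oc(=O)n(CCC(=O)O)c3cc2Cl)c1` is not yet measured and differs from compound 2 by 4-methylpyridin-2-yl in place of hydrogen on a saturated chain carbon bound to an oxygen on an aromatic ring and a saturated chain carbon. The group entering is an isomer of the one that left in a 63-fold higher number from compound 1 to compound 2 (1.80 log units; beyond the scatter), at the same place, so that step is the only one that bears on the change. A large fall in the number is therefore expected, estimated as a 40-fold lower number from compound 2 to compound 3 (1.60 log units; beyond the scatter). Compound 3 is estimated at 10 nM, with a range from 3 nM to 40 nM.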

Compound 3, half-maximal inhibitory concentration: 31600 nM
Compound 3: the middle estimate sits 3200-fold (3.50 log units) below what was measured; the whole stated range lies below it.
By their numbers in this assay, from the lowest: compound 1; then compound 2; then compound 3.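

With 4-methylpyridin-2-yl in place of hydrogen on this saturated chain carbon, this assay shows the number rising (a 79-fold higher number from compound 2 to compound 3 (1.90 log units; beyond the scatter)), opposite to the fall seen with 5-methylpyridin-2-yl, so a methylpyridin-2-yl group at this place does not by itself lower the number. The exchange between the two isomeric groups gives the widest gap in the series (a 5000-fold higher number from compound 1 to compound 3 (3.70 log units; beyond the scatter)), so the outcome here depends on which isomer is present. Nothing measured here explains that gap.

Still open, as far as these compounds go, is how the unsubstituted pyridin-2-yl or a phenyl group would read at this carbon. Also open, from the compounds shown here alone, is whether a methoxy group in place of the methyl on the pyridine ring would follow either isomer.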